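Swapping a Methoxyphenyl for a Furan at the Chain End

This account rests on a few compounds, and the source may have more. Where it says the series, first, only, none or still open, it means among the compounds named here.

This set of compounds shares a core made of two double-bonded chain carbons flanking a carbonyl, with a triazole linker that carries a coumarin-type tail. For the measured compounds named here, compound 1, `COc1ccccc1/C=C/C(=O)/C=C/c1ccc(OCc2cn(CCOc3cc(=O)oc4ccccc34)nn2)c(OC)c1`, is the only member with a number in a functional assay on PC-3 cells (Homo sapiens) for inhibition, read by sulforhodamine B assay, with a stated time of 48 h, tested at 50 uM; on this read-out higher numbers stand for more inhibition of growth at the one concentration tested and lower numbers for less inhibition of growth: in this assay compound 1 gives 11%, which is a weak effect at the single concentration tested. Compound 2, `COc1cc(/C=C/C(=O)/C=C/c2cccs2)ccc1OCc1cn(CCCCCOc2cc(=O)oc3ccccc23)nn1`, is reported in this assay as "not active" (no number reported), and compound 3, `COc1cc(/C=C/C(=O)/C=C/c2ccco2)ccc1OCc1cn(CCCCOc2cc(=O)oc3ccccc23)nn1`, is likewise reported as "not active" (no number reported); neither gives a figure to compare.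

Compound 4, `COc1cc(/C=C/C(=O)/C=C/c2ccco2)ccc1OCc1cn(CCOc2cc(=O)oc3ccccc23)nn1`, has not yet been measured. It differs from compound 1 in one place: furan-2-yl in place of 2-methoxyphenyl on a double-bonded chain carbon bound to a double-bonded chain carbon. Going by the values given here, the chain joining the triazole to the coumarin-type tail is the same length as in compound 1, whereas compounds 2 and 3 carry longer chains, so no measured pair isolates the effect of the ring swap alone.

Given that compound 1 already sits near the bottom of the scale at 11%, and that the furan-bearing compound 3 gave no number at all, the step from compound 1 to compound 4 is expected to be small or absent, a number 3 percentage points lower from compound 1 to compound 4 (within the scatter), not beyond the usual scatter. Compound 4 is therefore estimated to give 8% in this assay, within a range of 0% to 20%.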

Compound 4, percent growth inhibition at one concentration: 14%
Compound 4: middle estimate off by 6 percentage points, on the low side; low and high end bracket the measured number.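

In this assay, for the compounds shown here, furan-2-yl in place of 2-methoxyphenyl on a double-bonded chain carbon bound to a double-bonded chain carbon gives a number 3 percentage points higher from compound 1 to compound 4 (within the scatter), the first step that isolates this ring swap. At this chain length, then, a ring of 5 heavy atoms and one of 8 heavy atoms cannot be told apart in this test. Compound 3 carries the same furan-2-yl on a longer chain to the coumarin-type tail and is reported as not active, whereas compound 4 gives 14%, but without a number for compound 3 no step can be read; nothing available explains why compound 1 and compound 4 read so alike.

From the compounds shown here alone, both compounds sit low on this scale, so it remains open whether any other group at this place, such as a ring carrying an amine or a carboxylic acid, could give clearly stronger growth inhibition. Also open is what the same ring swap does when the chain to the tail is longer, since no numbers are shown for those compounds.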